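Compound 3 to compound 4: changing the acyl group

This account rests on a few compounds, and the source may have more. Where it says the series, first, only, none or still open, it means among the compounds named here.

Values in a functional assay on NCI-H1975 cells (Homo sapiens) for antiproliferative activity (on this read-out lower numbers stand for stronger inhibition and higher numbers for weaker inhibition), so far:
compound 1 `Cc1c2c(n3c1CCCN(C)[C@@H](C)[C@H](C)Nc1cc-3ccc1C(N)=O)CC(C)(C)CC2=O` gives 69 nM
compound 2 `CC(=O)N1CCCc2c(C)c3c(n2-c2ccc(C(N)=O)c(c2)N[C@@H](C)[C@@H]1C)CC(C)(C)CC3=O` gives 20 nM
compound 3 `Cc1c2c(n3c1CCN(C(=O)CN)C[C@@H](C)[C@H](C)Nc1cc-3ccc1C(N)=O)CC(C)(C)CC2=O` gives 190 nM

Compound 3 holds the highest number of the three, and compound 1 and compound 2 both lie beyond the scatter from it. Next is compound 4 `Cc1c2c(n3c1CCN(C(=O)[C@@H](O)C(C)C)C[C@@H](C)[C@H](C)Nc1cc-3ccc1C(N)=O)CC(C)(C)CC2=O` with the change 1-hydroxy-2-methylpropyl in place of aminomethyl on a carbonyl carbon. For the measured compounds named here, the only measured step, a 3.5-fold lower number from compound 1 to compound 2 (0.54 log units; beyond the scatter) for acetyl in place of methyl on an amine nitrogen in a ring, is modest and does not test this change directly. Compound 2 still gives 20 nM without any aminomethyl, so a modest move to a lower number is expected, with a wide range. The expected move is a 2.4-fold lower number from compound 3 to compound 4 (0.38 log units; beyond the scatter) by this estimate. Compound 4 is estimated at 80 nM with an expected range of 25 nM to 250 nM in this read-out.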

Compound 4, half-maximal inhibitory concentration: 31 nM
Estimate against measurement, compound 4: 2.6-fold (0.41 log units) above, and the stated range covers the measured number.
By their numbers in this assay, from the lowest: compounds 2 and 4 (each within the scatter of the next); then compound 1; then compound 3.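

In this assay, 1-hydroxy-2-methylpropyl in place of aminomethyl, on a carbonyl carbon attached to an amide-type nitrogen in a ring, gives a 6.1-fold lower number from compound 3 to compound 4 (0.79 log units; beyond the scatter). For the compounds shown here, this is the first step read at this position, and it shows that the group on this carbonyl carbon can shift the read-out beyond the scatter. Nothing at hand explains the step.

Whether the hydroxyl or the branched carbon chain accounts for the step remains open; hydroxymethyl or 2-methylpropyl on the same carbonyl carbon would separate the two. As far as these compounds go, the effect of the opposite configuration at the new stereocentre also remains open.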